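The compounds below may be only part of what the source reports. "The series", "measured", "known", "first", "only" and "open" are said of these compounds alone.

Measured in a functional assay on ACHN cells (Homo sapiens); on this read-out lower numbers stand for stronger inhibition of growth and higher numbers for weaker inhibition of growth:
- Compound 1 `O=S(=O)(/C=C/c1ccccc1)Cc1ccc(Nc2ncnc3ccccc23)cc1`: 58000 nM
- Compound 2 `N#Cc1ccc(/C=C/S(=O)(=O)Cc2ccc(Nc3ncnc4ccccc34)cc2)cc1`: > 100000 nM (a limit)
- Compound 3 `CC(C)(C)c1cc(/C=C/S(=O)(=O)Cc2ccc(Nc3ncnc4ccccc34)cc2)cc(C(C)(C)C)c1O`: > 100000 nM (a limit)

Compound 2 gives only a limit and no number. It sits at the limit of > 100000 nM in this assay, at which 2 of the 3 values shown sit. Compound 4 `O=S(=O)(/C=C/c1ccc(Cl)cc1)Cc1ccc(Nc2ncnc3ccccc23)cc1` differs from compound 2 by one group (chloro in place of cyano on an aromatic carbon): chloro in place of cyano on an aromatic carbon. Among the compounds with values here, the only measured step bearing on this is an at least 1.7-fold higher number from compound 1 to compound 2 (0.23 log units; that floor lies within the scatter), which replaced hydrogen with cyano. Within the data shown here, with only that step to go on, and with compound 1 at 58000 nM, a modest move to a lower number in this assay is expected, perhaps none beyond the scatter. The expected step is an at least 1.5-fold lower number from compound 2 to compound 4 (0.18 log units; that floor lies within the scatter). The estimate for compound 4 is 65000 nM, with an expected range of 25000 nM to 130000 nM.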

Compound 4, concentration for 50% growth inhibition: > 100000 nM
Compound 4: only a limit was reported; the forecaster's own chance of this, stated with the estimate: 35%; middle value at least 1.5-fold (0.18 log units) away from the limit.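

In this assay compound 4 gives only a limit, > 100000 nM. Chloro in place of hydrogen gives an at least 1.7-fold higher number from compound 1 to compound 4 (0.23 log units; that floor lies within the scatter), so a second group at this place shows no lower number than hydrogen, while the step between compound 2 and compound 4 cannot be read, as both values are limits. The values now gather at one ceiling: the limit of > 100000 nM in this assay, at which 3 of the 4 values shown sit.

From the compounds shown here alone, whether any group at this place can bring the number below that of compound 1 stays open. An amine or a methoxy group there would be one test of this.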